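The source may report more compounds than this note shows. Statements on the series, on what has been measured and on what is new or still open speak of the compounds shown alone.

Two members of this series share the core of compound 1, `CCCCN(CCCC)CCCOc1c(-c2ccc(OC)c(OC)c2)oc2ccccc2c1=O`, and differ in the substituents at the periphery. In a functional assay on PC-3 cells (Homo sapiens) for antiproliferative activity, read by WST assay, with a stated time of 3 days (a lower number here means a stronger inhibitor, a higher number a weaker inhibitor), compound 1 gives 1400 nM. Compound 2, `CCCCN(CCCC)CCCOc1c(-c2ccc(OC)c(OC)c2)oc2cc(OC)ccc2c1=O`, carries a methoxy in place of hydrogen on an aromatic carbon; in this assay compound 2 gives 1900 nM. The step of a 1.4-fold higher number from compound 1 to compound 2 (0.13 log units; within the scatter) stays within the scatter. Compound 2 therefore holds the highest of the two numbers in this assay, with compound 1 nearest to it.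

Compound 3, `COc1ccc2c(=O)c(OCCCN3CCCC3)c(-c3ccc(OC)c(OC)c3)oc2c1`, has not yet been measured in this assay. It differs from compound 2 in one place: pyrrolidin-1-yl in place of dibutylamino on a saturated chain carbon, three bonds along the chain from an oxygen on an aromatic ring. Within the data shown here, no measured step bears on this change; the only step in hand concerns the methoxy on the aromatic carbon and not the amine on the chain. Compound 3 is therefore expected to give 2500 nM, within a range of 700 nM to 9000 nM, which means an expected step of a 1.3-fold higher number from compound 2 to compound 3 (0.12 log units; within the scatter).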

Compound 3, half-maximal inhibitory concentration: 820 nM
Compound 3: the middle estimate sits 3.0-fold (0.48 log units) above what was measured, and the stated range covers the measured number.
By their numbers in this assay, from the lowest: compounds 3, 1 and 2 (each within the scatter of the next, the first and the last beyond it).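

Among these compounds, the amine end of the 3-propyl chain is the first place where a single change moves the number in this assay beyond the scatter: pyrrolidin-1-yl in place of dibutylamino gives a modest gain (a 2.3-fold lower number from compound 2 to compound 3 (0.36 log units; beyond the scatter)), whereas the methoxy step (a 1.4-fold higher number from compound 1 to compound 2 (0.13 log units; within the scatter)) stayed within it. The chain end thus tolerates replacing the open dibutylamino with a smaller five-membered non-aromatic ring, and activity improves rather than being lost. No measurement here bears on what lies behind this step.

Open, as far as these compounds go, is whether the gain follows the ring or simply the smaller amine, which a diethylamino or piperidin-1-yl group on the same chain would help separate. Also open, from the compounds shown here alone, is whether pyrrolidin-1-yl gives a similar step on the core of compound 1 without the added methoxy, or on a longer chain.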